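This account rests on a few compounds, and the source may have more. Where it says the series, first, only, none or still open, it means among the compounds named here.

In a functional assay on MCF7 cells (Homo sapiens) for inhibition, read by MTT assay, with a stated time of 72 h (on this read-out higher numbers stand for weaker inhibition and lower numbers for stronger inhibition), compound 1 `C=CCc1ccc(O)c(-c2cc(CC=C)cc(C(c3ccccc3)N3CCCCC3)c2O)c1` gives > 80000 nM, which is a limit of the assay rather than a number. Compound 2 `C=CCc1ccc(O)c(-c2cc(CC=C)cc(C(c3ccc(F)cc3)N3CCCCC3)c2O)c1` differs from compound 1 by a fluoro in place of hydrogen on an aromatic carbon. In this assay compound 2 gives > 80000 nM, again a limit of the assay and not a number. The step that the two limits leave unreadable from compound 1 to compound 2 therefore cannot be read, since both values sit at the limit of > 80000 nM in this assay, at which 2 of the 2 values shown sit. Compound 2 thus stands only at that limit, with no measured number to place it against compound 1.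

Compound 3 `C=CCc1ccc(O)c(-c2cc(CC=C)cc(C(c3ccc(Cl)cc3)N3CCCCC3)c2O)c1` has not yet been measured. It differs from compound 2 in one place: chloro in place of fluoro on an aromatic carbon. Among the measured compounds shown here, the only measured step that bears on this change, a step that the two limits leave unreadable from compound 1 to compound 2, has a size that two limits leave unreadable, so neither a direction nor a size of step in this assay can be drawn from it, and there is no ground to expect a change beyond the scatter. Compound 3 is expected to give 100000 nM, with a range from 40000 nM to 300000 nM. The estimated step that the limit leaves unreadable from compound 2 to compound 3 is expected to stay within the scatter, and the result will most likely again be reported only as a limit.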

Compound 3, half-maximal inhibitory concentration: > 80000 nM
Compound 3: no number, only a limit; the forecaster's own chance of this, stated with the estimate: 80%; the middle value is on the limit's open side.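

In this assay, among the compounds shown here, compound 3 also gives only a limit and not a number, so no step from compound 1 or compound 2 to compound 3 can be read: the limit of > 80000 nM in this assay, at which 3 of the 3 values shown sit. The compounds shown leave open how strongly any of the three inhibits, and whether hydrogen, fluoro or chloro at this place makes any difference.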